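Alkyne-to-aromatic swap on the shared core: clearance notes

The source may report more compounds than this note shows. Statements on the series, on what has been measured and on what is new or still open speak of the compounds shown alone.

Compound 1 `CC(C)(O)C#Cc1cc(C(O)(C(F)(F)F)C(F)(F)F)cnc1N1CCN(S(=O)(=O)c2ccc(N)nc2)CC1` carries a 3-hydroxy-3-methylbut-1-yn-1-yl group on an aromatic carbon of the shared core. In an ADME assay (liver) for metabolic stability, with Liver microsome (Rattus norvegicus) as the target, using microsomes and NADPH, with a stated time of 30 min, tested at 1 uM (a lower number here means slower removal, a higher number faster removal of the compound), compound 1 gives 16 mL.min-1.g-1, the lowest of the two numbers in hand. Going by the values given here, its only measured neighbour is compound 2 `Nc1ccc(S(=O)(=O)N2CCN(c3ncc(C(O)(C(F)(F)F)C(F)(F)F)cc3-c3ccoc3)CC2)cn1`, which in this assay gives 57 mL.min-1.g-1; the step of a 3.6-fold higher number from compound 1 to compound 2 (0.55 log units; beyond the scatter) is the one comparison available.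

Compound 3 `Nc1ccc(S(=O)(=O)N2CCN(c3ncc(C(O)(C(F)(F)F)C(F)(F)F)cc3-c3ccc4ocnc4c3)CC2)cn1` has not yet been measured. It differs from compound 1 by 1,3-benzoxazol-5-yl in place of 3-hydroxy-3-methylbut-1-yn-1-yl on an aromatic carbon. The measured step that bears on this change is a 3.6-fold higher number from compound 1 to compound 2 (0.55 log units; beyond the scatter), in which the same 3-hydroxy-3-methylbut-1-yn-1-yl group gave way to furan-3-yl, a group that, like 1,3-benzoxazol-5-yl, brings a five-membered aromatic ring with hetero atoms and leaves no hydrogen-bond donor. Among the compounds with values here, no measured step shows what the additional six-membered aromatic ring of carbon only contributes, so the size of the step is less certain than its direction. A rise of a similar order is therefore expected, a 3.1-fold higher number from compound 1 to compound 3 (0.49 log units; beyond the scatter). For compound 3 the expected value in this assay is 50 mL.min-1.g-1, within a range from 20 mL.min-1.g-1 to 130 mL.min-1.g-1.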

Compound 3, intrinsic clearance in microsomes: 120 mL.min-1.g-1
For compound 3 the middle estimate is 2.4-fold (0.38 log units) below the measured one; measured number inside the range.
By their numbers in this assay, from the lowest: compound 1; then compound 2; then compound 3.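

Notes on the swap at this position: in this assay, 1,3-benzoxazol-5-yl in place of 3-hydroxy-3-methylbut-1-yn-1-yl gives a 7.5-fold higher number from compound 1 to compound 3 (0.88 log units; beyond the scatter), so a second aromatic replacement also ends above compound 1, and the rise seen with furan-3-yl is no longer a single case. Nothing among the three compounds goes against this, but the two aromatic groups do not behave as one class: 1,3-benzoxazol-5-yl in place of furan-3-yl gives a 2.1-fold higher number from compound 2 to compound 3 (0.32 log units; beyond the scatter), so the number at this position depends on which aromatic group is present, not only on the replacement of the alkyne group. What lies behind either step is not addressed by any measurement available for this series.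

The compounds shown do not separate the hydroxyl from the triple bond within the group of compound 1, and a saturated 3-hydroxy-3-methylbutyl chain or a 3-methoxy-3-methylbut-1-yn-1-yl group would bear directly on that. As far as these compounds go, with one single-ring group and one two-ring group in hand, it also remains open whether the order of compound 2 and compound 3 follows ring count or the identity of the group, which a plain phenyl or a pyridine ring could help to settle.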